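A few compounds are considered here, and "the series" means these few. Any claim that something is new, unique, unknown or untested is made for them only; others in the source may bear on it.

Measured in a functional assay on KBVIN cells (Homo sapiens) for antiproliferative activity, read by sulforhodamine B assay, with a stated time of 3 days; a higher number here means that more compound is needed for the effect, a lower number that less compound is needed:
compound 1 `CCCCc1ccc(-c2cc(=O)c3c(o2)C(CC)(CC)C(=O)C(CC)=C3O)cc1` gives 37 uM
compound 2 `CCC1=C(O)c2c(oc(-c3ccc(CC(C)C)cc3)cc2=O)C(CC)(CC)C1=O` gives 17.4 uM
compound 3 `CCC1=C(O)c2c(oc(-c3ccc(COC)cc3)cc2=O)C(CC)(CC)C1=O` gives 3.4 uM

Compound 3 gives the lowest number of the three in this assay; the nearest is compound 2, with a 5.1-fold lower number from compound 2 to compound 3 (0.71 log units; beyond the scatter), and the furthest is compound 1, with an 11-fold lower number from compound 1 to compound 3 (1.04 log units; beyond the scatter). Compound 4 `CCC1=C(O)c2c(oc(-c3ccc(OC)c(F)c3)cc2=O)C(CC)(CC)C1=O` differs from compound 3 by 3-fluoro-4-methoxyphenyl in place of 4-(methoxymethyl)phenyl on an aromatic carbon. No measured step covers this exchange directly: the shown steps only swap groups on a saturated chain carbon bound to an aromatic carbon, and they were a 2.1-fold lower number from compound 1 to compound 2 (0.33 log units; beyond the scatter) and an 11-fold lower number from compound 1 to compound 3 (1.04 log units; beyond the scatter). Those steps show that the aryl group matters, but nothing shows which way this particular change goes. Compound 4 is therefore expected to sit near compound 3, with a 1.8-fold higher number from compound 3 to compound 4 (0.25 log units; within the scatter) as the estimated step. The estimate for compound 4 is 6 uM, range 2 uM to 20 uM.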

Compound 4, concentration for half-maximal effect: 0.1 uM
Compound 4: middle estimate off by 60-fold (1.78 log units), on the high side; the whole stated range lies above it.
By their numbers in this assay, from the lowest: compound 4; then compound 3; then compound 2; then compound 1.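

In this assay, among these compounds, 3-fluoro-4-methoxyphenyl in place of 4-(methoxymethyl)phenyl gives a 34-fold lower number from compound 3 to compound 4 (1.53 log units; beyond the scatter), the largest step so far. This aryl position therefore responds strongly to a change that leaves the heavy-atom count unchanged, and a direct ring methoxy with fluorine is far better here than the chain-linked groups seen before. No available evidence explains this drop.

The compounds shown do not separate the contribution of the fluorine from that of the methoxy, which 4-methoxyphenyl would address. On these data alone, what an amine in place of the methoxy would do also remains open.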